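Replacing the aryl group of compound 2 with 2-methoxyphenyl

The compounds below may be only part of what the source reports. "The series", "measured", "known", "first", "only" and "open" are said of these compounds alone.

In a functional assay on A549 cells (Homo sapiens) for antiproliferative activity, read by MTT assay, with a stated time of 72 h (a higher number here means a weaker inhibitor, a lower number a stronger inhibitor), compound 1 (`COc1ccc(-c2c(C(=O)c3cc(OC)c(OC)c(OC)c3)sc3ccccc23)cc1`) gives 4400 nM and compound 2 (`COc1cc(C(=O)c2sc3ccccc3c2-c2ccc(SC)cc2)cc(OC)c1OC`) gives 5400 nM as its half-maximal inhibitory concentration. Among the measured compounds shown here, compound 2 thus stands level with compound 1, the only other compound measured, and their two values lie within the scatter of each other.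

Compound 3 (`COc1ccccc1-c1c(C(=O)c2cc(OC)c(OC)c(OC)c2)sc2ccccc12`) has not yet been measured. It differs from compound 2 in one place, with 2-methoxyphenyl in place of 4-(methylsulfanyl)phenyl on an aromatic carbon of the five-membered aromatic ring (2-methoxyphenyl in place of 4-(methylsulfanyl)phenyl on an aromatic carbon). For the measured compounds named here, the only measured step that bears on this change is the exchange of methoxy for methylsulfanyl, which gives a 1.2-fold higher number from compound 1 to compound 2 (0.09 log units; within the scatter) and stays within the scatter. Going by the values given here, no measured compound carries 2-methoxyphenyl, so the data offer only indirect guidance and the range has to stay wide.

An estimated 1.1-fold higher number from compound 2 to compound 3 (0.05 log units; within the scatter) is therefore expected, with no shift beyond the scatter in either direction. Compound 3 is expected at about 6000 nM in this assay with an estimated range from 2000 nM to 18000 nM around that figure.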

Compound 3, half-maximal inhibitory concentration: > 10000 nM
Compound 3: a limit, no number; the forecaster's own chance of this, stated with the estimate: 15%; middle value at least 1.6-fold (0.22 log units) away from the limit.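

In this assay compound 3 gives > 10000 nM, which is a limit of the assay and not a number. The exchange of 4-(methylsulfanyl)phenyl for 2-methoxyphenyl gives an at least 1.8-fold higher number from compound 2 to compound 3 (0.26 log units; that floor lies within the scatter), so this comparison alone does not establish a loss. The clearer reading comes from the exchange of 4-methoxyphenyl for 2-methoxyphenyl, which gives an at least 2.2-fold higher number from compound 1 to compound 3 (0.35 log units; beyond the scatter); the earlier exchange of methoxy for methylsulfanyl gave only a 1.2-fold higher number from compound 1 to compound 2 (0.09 log units; within the scatter), whereas this result shows that the number at this aromatic carbon of the five-membered ring can respond to a change of aryl group.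

As far as these compounds go, how far the true value of compound 3 lies past its limit stays open, and with it the full size of both new steps: the limit of > 10000 nM in this assay, at which 1 of the 3 values shown sits. Also open is how an aryl group carrying an amine, a hydroxyl or a longer chain such as butoxy would behave on this same carbon, and whether 3-methoxyphenyl would stand with 4-methoxyphenyl or with 2-methoxyphenyl.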